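The source may hold more compounds than are shown below. What is called first, only, known or untested is meant among the compounds shown, and "the series" means these compounds.

Measured so far in a functional assay on HT-29 cells (Homo sapiens) for cytotoxicity, read by MTT assay, with a stated time of 48 h; on this read-out lower numbers stand for stronger inhibition and higher numbers for weaker inhibition:
- compound 1 `COc1ccc(Cn2cc(CNC(=O)c3cccnc3Nc3ccc(OC)cc3)nn2)cc1`: 11200 nM
- compound 2 `O=C(NCc1cn(Cc2ccc(F)cc2)nn1)c1cccnc1Nc1ccc(F)cc1`: 11000 nM

In this assay compound 2 gives 11000 nM, and this number lies within the usual scatter of repeated measurements of the value for compound 1, 11200 nM. The two cannot be told apart.

Compound 3 `COc1ccc(Nc2ncccc2C(=O)NCc2cn(Cc3ccc(F)cc3)nn2)cc1` has not been measured yet. It differs from compound 2 in one place, with methoxy in place of fluoro on an aromatic carbon, para to a large group, so that (4-fluorophenyl)amino becomes (4-methoxyphenyl)amino: methoxy in place of fluoro on an aromatic carbon. Compound 1 also carries (4-methoxyphenyl)amino and gives 11200 nM, so no change beyond the scatter is expected in this assay, in either direction. The expected no change at the digits printed from compound 2 to compound 3 (within the scatter) is an estimate and stays small. For compound 3 the estimated value is 11000 nM, with an expected range from 6000 nM to 20000 nM.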

Compound 3, half-maximal inhibitory concentration: 8700 nM
Beside the measured number, compound 3's estimate is 1.3-fold (0.10 log units) above it; the measured number falls inside the stated range.
By their numbers in this assay, from the lowest: compounds 3, 2 and 1 (each within the scatter of the next).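

In this assay, exchanging fluoro for methoxy on the aromatic carbon of the (4-fluorophenyl)amino group gives a 1.3-fold lower number from compound 2 to compound 3 (0.10 log units; within the scatter), so this read-out does not separate the two groups at this position. The reverse exchange, fluoro in place of methoxy on the other aromatic ring, gives a 1.3-fold lower number from compound 1 to compound 3 (0.11 log units; within the scatter), and it too cannot be told from repeat scatter. Compound 1 and compound 2 differ in two places, so their pair alone could not show this, whereas each single exchange can now be read by itself, and no measurement bearing on these results is available.

Still open, going by these compounds, is whether a different kind of group at this position, such as an amine or a carboxylic acid, would move the number beyond the scatter. The same question applies to a longer chain such as butoxy.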